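The source may report more compounds than this note shows. Statements on the series, on what has been measured and on what is new or still open speak of the compounds shown alone.

Compound 1 `COc1ccc(-c2ccc(-c3ccc(C(=N)N)o3)o2)cc1` is one of three compounds that have been examined in an ADME assay on cells (Erythrocyte, Homo sapiens) for activation, read by hemolysis, with a stated time of 30 min, tested at 0.625 mM; a lower number here means a weaker effect, a higher number a stronger effect of the compound at the concentration tested. For compound 1 the assay gives "non-toxic" (no number reported), so it stands without a single number. Its thiophene counterpart, compound 2 `COc1ccc(-c2ccc(-c3ccc(C(=N)N)s3)s2)cc1`, gives 4% in this assay, and compound 3 `COc1cc(OC)cc(-c2ccc(-c3ccc(C(=N)N)o3)o2)c1` is likewise reported as "non-toxic" (no number reported) in this assay. The account now turns to compound 4 `N=C(N)c1ccc(-c2ccc(-c3ccccc3)o2)o1`, which differs from compound 1 by hydrogen in place of methoxy on an aromatic carbon. For the measured compounds named here, no measured step shows what this change does in this assay; given that the three measured compounds are all weak, the expected step is none beyond the scatter, in either direction. Compound 4 is therefore expected to give 4% in this assay, within a range from 0% to 14%.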

Compound 4, a percentage reported as activity, at one concentration (the size of the read-out at that concentration, not a potency): "non-toxic" (no number reported)
Compound 4 has no reported number here; no gap can be computed for the estimate.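

In this assay compound 1 gives "non-toxic" (no number reported) and compound 4 gives "non-toxic" (no number reported) so no step can be read between them. No evidence bears on this result. Going by these compounds, whether hydrogen in place of methoxy changes the read-out at all stays open.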